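Swapping the chlorophenyl of compound 2 for a pyridine

The compounds below may be only part of what the source reports. "The series", "measured", "known", "first", "only" and "open" are said of these compounds alone.

Measured compounds:
- compound 1, `O=C(O)CCSC(=S)NCc1cccnc1`: 7970 nM
- compound 2, `S=C(NCc1cccnc1)SCCc1nnc(-c2ccc(Cl)cc2)o1`: 860 nM

Both compounds were tested in a functional assay on SK-BR-3 cells (Homo sapiens) for cytotoxicity, read by resazurin assay, with a stated time of 72 h; on this read-out higher numbers stand for weaker inhibition and lower numbers for stronger inhibition. Compound 1 gives 7970 nM. Compound 2 stands as the lowest of the two numbers, with 860 nM, and the gap to compound 1 lies beyond the usual scatter.

Compound 3, `S=C(NCc1cccnc1)SCCc1nnc(-c2cccnc2)o1`, has not yet been measured in this assay. It differs from compound 2 in one place: pyridin-3-yl in place of 4-chlorophenyl on an aromatic carbon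

Within the data shown here, no pair of measured compounds shows a change of this kind, so its size cannot be read from the data at hand. For compound 3 the expected step in this assay is a 1.7-fold higher number from compound 2 to compound 3 (0.24 log units; within the scatter), a small move toward weaker inhibition that may well fall within the scatter. The estimated value for compound 3 is 1500 nM, within a range from 500 nM to 5000 nM.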

Compound 3, half-maximal inhibitory concentration: 800 nM
Estimate against measurement, compound 3: 1.9-fold (0.27 log units) above; measured number inside the range.
By their numbers in this assay, from the lowest: compounds 3 and 2 (each within the scatter of the next); then compound 1.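

In this assay, replacing 4-chlorophenyl with pyridin-3-yl gives a 1.1-fold lower number from compound 2 to compound 3 (0.03 log units; within the scatter), so compound 2 and compound 3 cannot be told apart on this read-out. This shows what a single group could not: the position on the five-membered aromatic ring keeps its number when a carbon-only ring carrying chlorine gives way to a ring with one nitrogen and one hydrogen-bond acceptor. Nothing measured here explains why the number holds.

Going by these compounds, it remains open whether this tolerance extends to other groups at this position, such as plain phenyl, pyridin-4-yl or a small alkyl group like methyl. The effect of placing an amine or a carboxylic acid on the aromatic ring at this position also remains to be seen.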